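Lengthening a Triamine Chain Lowers the Inhibitory Concentration

The source may hold more compounds than are shown below. What is called first, only, known or untested is meant among the compounds shown, and "the series" means these compounds.

Measured compounds:
compound 1 `CCNCCCNCCCN` — > 100000 nM
compound 2 `CCNCCCCNCCCN` — 40000 nM
compound 3 `CCNCCCCNCCCNCC` — 700 nM

Three short chain amines were tested in a functional assay on L1210 cells (Mus musculus) for inhibition, with a stated time of 96 h; a higher number here means a weaker inhibitor, a lower number a stronger inhibitor. For compound 1 the result is only a limit of the assay, > 100000 nM, not a number. Compound 2 gives 40000 nM, and compound 3 gives 700 nM.

The step (ethylamino)methyl in place of ethylamino on a saturated chain carbon, three bonds along the chain from an amine nitrogen brings an at least 2.5-fold lower number from compound 1 to compound 2 (0.39 log units; beyond the scatter); this step is known only as a lower bound because of the limit of > 100000 nM in this assay, at which 1 of the 3 values shown sits. The second step, ethyl in place of hydrogen on an amine nitrogen, brings a 57-fold lower number from compound 2 to compound 3 (1.76 log units; beyond the scatter). Taken together, the cores of compound 1 and compound 3 differ by (ethylamino)methyl in place of amino on a saturated chain carbon, three bonds along the chain from an amine nitrogen, and the whole distance is an at least 140-fold lower number from compound 1 to compound 3 (2.15 log units; beyond the scatter).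

Compound 4 `CCNCCCCNCCCCNCC` has not yet been measured. It differs from compound 3 by (ethylamino)methyl in place of ethylamino on a saturated chain carbon, three bonds along the chain from an amine nitrogen, the same change as that from compound 1 to compound 2, at the same place. In this assay that earlier change gave an at least 2.5-fold lower number from compound 1 to compound 2 (0.39 log units; beyond the scatter). Since the starting point is now compound 3 with 700 nM, a more modest gain is expected, and the step is estimated as a 2.3-fold lower number from compound 3 to compound 4 (0.37 log units; beyond the scatter). For compound 4 the estimated value in this assay is 300 nM, with a likely range from 80 nM to 1200 nM.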

Compound 4, half-maximal inhibitory concentration: 350 nM
Compound 4: the middle estimate sits 1.2-fold (0.07 log units) below what was measured, and the stated range covers the measured number.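

Carried onto the core of compound 3, the change from ethylamino to (ethylamino)methyl gives a 2.0-fold lower number from compound 3 to compound 4 (0.30 log units; within the scatter) in this assay and so, on this core, cannot be told apart from no change at all, whereas the wider change from amino to (ethylamino)methyl stays large, with a 110-fold lower number from compound 2 to compound 4 (2.06 log units; beyond the scatter). Set beside its earlier reading on the core of compound 1, the smaller change shows no firm difference between the two cores, but it does not show that the size of the step carries over unaltered either: the same change on two cores in this assay, an at least 2.5-fold lower number (0.39 log units; beyond the scatter) from compound 1 to compound 2 and a 2.0-fold lower number (0.30 log units; within the scatter) from compound 3 to compound 4; the limit leaves it open whether they differ. The wider change is large on both pairs of compounds, which fits a step that travels well from one core to another in this short series, although an exact match between the two readings is not shown: the same change on two cores in this assay, an at least 140-fold lower number (2.15 log units; beyond the scatter) from compound 1 to compound 3 and a 110-fold lower number (2.06 log units; beyond the scatter) from compound 2 to compound 4; the limit leaves it open whether they differ.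

From the compounds shown here alone, it stays open whether a longer chain between the amine nitrogens would lower the number further or whether the trend ends here. Equally open, going by these compounds, is how a propyl or benzyl group in place of ethyl on the end amine nitrogens would behave, and whether any of these steps would hold in cells other than the L1210 line.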